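A few compounds are considered here, and "the series" means these few. Any claim that something is new, unique, unknown or untested is made for them only; others in the source may bear on it.

Working notes on the series. Compound 1 `FC(F)(F)c1ccc(C(c2ccccc2)N2CCN(c3ncnc4c3cnn4-c3ccccc3)CC2)cc1`, compound 2 `Cc1ccccc1C(c1sccc1C)N1CCN(c2ncnc3c2cnn3-c2ccccc2)CC1` and compound 3 `Cc1ccsc1C(c1ccccc1Br)N1CCN(c2ncnc3c2cnn3-c2ccccc2)CC1` share one core and differ only in the two aryl groups on the benzylic carbon. In a functional assay on cells (Rhabdomyosarcoma cell, Homo sapiens) for cytotoxicity (a higher number here means a weaker inhibitor, a lower number a stronger inhibitor), compound 1 reaches only the limit of the assay, > 25000 nM. Compound 2 likewise stops at a limit, > 25000 nM. Compound 3 also gives a limit in this assay, > 25000 nM. The step that the two limits leave unreadable from compound 2 to compound 3 is therefore unreadable, all three values resting on the same limit (the limit of > 25000 nM in this assay, at which 3 of the 3 values shown sit). Compound 4 `Cc1ccsc1C(c1ccccc1)N1CCN(c2ncnc3c2cnn3-c2ccccc2)CC1` differs from compound 3 by hydrogen in place of bromo on an aromatic carbon. Within the data shown here, no measured step bears readably on this change, and nothing suggests a departure from the limit. Compound 4 is expected near 35000 nM, within 8000 nM to 150000 nM. The estimated step that the limit leaves unreadable from compound 3 to compound 4 is accordingly expected to stay within the scatter.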

Compound 4, half-maximal inhibitory concentration: > 25000 nM
Compound 4: only a limit was reported; the forecaster's own chance of this, stated with the estimate: 80%; the middle value lies beyond the limit too.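

Compound 4 gives only a limit, > 25000 nM. Its steps from compound 1, compound 2 and compound 3 therefore cannot be read: the limit of > 25000 nM in this assay, at which 4 of the 4 values shown sit.

The compounds shown leave open which pair of aryl groups, if any, would give a measurable value in this assay.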